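Working notes: from compound 2 to compound 3

A few compounds are considered here, and "the series" means these few. Any claim that something is new, unique, unknown or untested is made for them only; others in the source may bear on it.

Values measured so far in a functional assay on MIA PaCa-2 cells (Homo sapiens) for inhibition, read by MTT assay, with a stated time of 48 h, tested at 10 uM (a lower number here means less inhibition of growth, a higher number more inhibition of growth at the concentration tested), are these
- compound 1 `Cc1cc(=O)c2c(O)cc(OCc3ccco3)c([C@H]3CCN(C)C[C@H]3O)c2o1` gives 7%
- compound 2 `Cc1cc(=O)c2c(O)c(CN3CCCC3CO)c(O)c([C@H]3CCN(C)C[C@H]3O)c2o1` gives 13%

In this assay compound 2 at 13% lies within the usual scatter of compound 1 at 7% and the two are not separated. Compound 3 `Cc1cc(=O)c2c(O)c(CN3CC(O)CC3C(=O)O)c(O)c([C@H]3CCN(C)C[C@H]3O)c2o1` carries 2-carboxy-4-hydroxypyrrolidin-1-yl in place of 2-(hydroxymethyl)pyrrolidin-1-yl on a saturated chain carbon bound to an aromatic carbon. No two measured compounds differ in one place only, so the series has not yet shown the size of any such change. The expectation therefore starts from compound 2 at 13% as the closest measured structure. No step beyond the scatter is expected in either direction, and the expected change is a number 3 percentage points lower from compound 2 to compound 3 (within the scatter) on this reading. The estimate for compound 3 is 10% with an expected range of 0% to 22% until the measurement is available.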

Compound 3, percent growth inhibition at one concentration: 23%
Compound 3: middle estimate off by 13 percentage points, on the low side; the whole stated range lies below it.
By their numbers in this assay, from the lowest: compounds 1, 2 and 3 (each within the scatter of the next, the first and the last beyond it).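

In this assay, the group on a saturated chain carbon bound to an aromatic carbon now has its first step in one place: 2-carboxy-4-hydroxypyrrolidin-1-yl in place of 2-(hydroxymethyl)pyrrolidin-1-yl gives a number 10 percentage points higher from compound 2 to compound 3 (within the scatter). This position thus carries two quite different substituted pyrrolidin-1-yl groups, with the larger of them, holding more oxygen, not separated from the smaller one. Nothing available bears on why the step has this size.

The carboxy and hydroxy groups enter together in compound 3, so their separate contributions remain unresolved. Also open, going by these compounds, is how the position responds to a pyrrolidin-1-yl group carrying only the carboxylic acid, or to a different amine such as morpholin-4-yl or dimethylamino.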